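The source may hold more compounds than are shown below. What is called first, only, known or untested is meant among the compounds shown, and "the series" means these compounds.

Measured so far in an ADME assay on L6 cells (Rattus norvegicus) for cytotoxicity, read by microscopy and resazurin assay, with a stated time of 72 h; a lower number here means that less compound is needed, a higher number that more compound is needed for the effect:

- compound 1 `Cc1cc(/C=C2\S/C(=N\c3ccccc3)N(C3CCCCC3)C2=O)c(C)n1-c1ccccc1`: > 200000 nM, a limit of the assay
- compound 2 `Cc1cc(/C=C2\S/C(=N\c3ccccc3)N(C3CCCCC3)C2=O)c(C)n1-c1cccc(C(F)(F)F)c1`: > 170000 nM, a limit of the assay
- compound 3 `Cc1cc(/C=C2\NC(=O)NC2=O)c(C)n1-c1ccccc1C(F)(F)F`: 84000 nM

Among the compounds with values here, compound 3 is the only one with a number; the other two values are limits, the limit of > 170000 nM in this assay, at which 1 of the 3 values shown sits, and (the limit of > 200000 nM in this assay, at which 1 of the 3 values shown sits). The change hydrogen in place of trifluoromethyl on an aromatic carbon therefore gives a step that the two limits leave unreadable from compound 2 to compound 1. How the core of compound 3 differs from that of compound 2 is not broken down here.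

Compound 4 `Cc1cc(/C=C2\NC(=O)NC2=O)c(C)n1-c1ccccc1` is not yet measured in this assay. It differs from compound 3 by hydrogen in place of trifluoromethyl on an aromatic carbon, the same kind of change as from compound 2 to compound 1, though there the group sits meta to a large group and here ortho to a large group. Since the measured step of that kind is unreadable, the expectation rests on compound 3 alone at 84000 nM: a step of about a 1.8-fold higher number from compound 3 to compound 4 (0.25 log units; within the scatter) is expected, so compound 4 is estimated at 150000 nM, between 60000 nM and 350000 nM.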

Compound 4, half-maximal effective concentration: > 320000 nM
Compound 4: no number, only a limit; the forecaster's own chance of this, stated with the estimate: 40%; middle value at least 2.1-fold (0.32 log units) from the limit.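

In this assay, hydrogen in place of trifluoromethyl on an aromatic carbon, ortho to a large group, gives an at least 3.8-fold higher number from compound 3 to compound 4 (0.58 log units; beyond the scatter) on the core of compound 3, a step beyond the scatter whose full size stays open, as the value of compound 4 is a limit: the limit of > 320000 nM in this assay, at which 1 of the 4 values shown sits.

On the core of compound 1, the same kind of change cannot be read, as compound 1 and compound 2 both carry limits. The series therefore shows the change on one core only and does not show whether it carries to another.

Open, going by these compounds, is how an amine or a carboxylic acid in place of trifluoromethyl would read in this assay on either core. Also open, on these data alone, is how a longer chain on the core of compound 3 would read there.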